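The compounds below may be only part of what the source reports. "The series", "measured", "known", "first", "only" and "open" are said of these compounds alone.

Compound 1 `O=[N+]([O-])c1c(CS(=O)(=O)c2ccccc2)nc2c(C#Cc3ccc(F)cc3)cc(Cl)cn12` is followed in an ADME assay on HepG2 cells (Homo sapiens) for cytotoxicity, read by MTT assay, with a stated time of 72 h; a lower number here means that less compound is tolerated, a higher number that more compound is tolerated. In this assay compound 1 gives > 3900 nM, which is a limit of the assay rather than a number. Compound 2 `Nc1ccc(C#Cc2cc(Cl)cn3c([N+](=O)[O-])c(CS(=O)(=O)c4ccccc4)nc23)cc1` gives > 3900 nM, again a limit. Compound 3 `O=[N+]([O-])c1c(CS(=O)(=O)c2ccccc2)nc2c(C#Cc3cccs3)cc(Cl)cn12` gives > 3900 nM, also a limit. All three values sit at the limit of > 3900 nM in this assay, at which 3 of the 3 values shown sit, so the step that the two limits leave unreadable from compound 1 to compound 2 and the step that the two limits leave unreadable from compound 1 to compound 3 cannot be sized. Compound 4 `O=[N+]([O-])c1c(CS(=O)(=O)c2ccccc2)nc2c(C#CCCO)cc(Cl)cn12` is not yet measured; it differs from compound 1 as follows: 2-hydroxyethyl in place of 4-fluorophenyl on a triple-bonded carbon. Neither measured step bears readably on this exchange of 4-fluorophenyl for 2-hydroxyethyl, and no change so far has brought any compound off the limit. Compound 4 is therefore expected to stay at the limit, the step that the limit leaves unreadable from compound 1 to compound 4 being expected to be small. The estimate for compound 4 is 6000 nM, within 2500 nM to 25000 nM.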

Compound 4, half-maximal cytotoxic concentration: > 125000 nM
Compound 4 ended at the assay's limit; the forecaster's own chance of this, stated with the estimate: 80%; middle value at least 20-fold (1.31 log units) from the limit.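

In this assay compound 4 gives > 125000 nM, a limit of the assay and not a number. For the compounds shown here, compound 1, compound 2 and compound 3 also stand at a limit, so no step to compound 4 can be read. Going by these compounds, the actual half-maximal cytotoxic concentration of all four compounds remains open.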